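Aryl swap on the carbonyl carbon of a chalcone-like series

The source may hold more compounds than are shown below. What is called first, only, known or untested is meant among the compounds shown, and "the series" means these compounds.

Three compounds share a core, differing in the aryl group attached to the carbonyl carbon or in a methoxy on the other aromatic ring. In a functional assay on HCT-116 cells (Homo sapiens) for cytotoxicity, read by sulforhodamine B assay, with a stated time of 48 h, tested at 0.01 uM (on this read-out lower numbers stand for a stronger effect and higher numbers for a weaker effect at the one concentration tested), compound 1 `COc1cc(-c2cc(/C=C/C(=O)c3ccc(N)cc3)[nH]n2)cc(OC)c1OC` gives 95%, compound 2 `COc1cc(-c2cc(/C=C/C(=O)c3ccc(Cl)c(Cl)c3)[nH]n2)cc(OC)c1OC` gives 102%, and compound 3 `COc1ccc(-c2cc(/C=C/C(=O)c3ccc(N)cc3)[nH]n2)cc1OC` gives 96%. Compound 2 holds the highest of the three numbers, but its gaps to compound 3 and to compound 1 both lie within the scatter, so the three read-outs cannot be told apart. Compound 4 `COc1ccc(C(=O)/C=C/c2cc(-c3cc(OC)c(OC)c(OC)c3)n[nH]2)cc1` has not yet been measured in this assay; it differs from compound 2 in one place: 4-methoxyphenyl in place of 3,4-dichlorophenyl on a carbonyl carbon. The step that bears most directly on this change is the earlier swap of the aryl group on the same carbonyl carbon, a number 7 percentage points higher from compound 1 to compound 2 (within the scatter), and the methoxy removal on the other ring, a number 1 percentage points higher from compound 1 to compound 3 (within the scatter), was likewise flat. All measured steps being within the scatter, no movement beyond the scatter is expected for compound 4 in this assay. The expected step is a number 5 percentage points lower from compound 2 to compound 4 (within the scatter). Compound 4 is therefore estimated at 97%, with a range of 86% to 108%.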

Compound 4, a percentage reported as activity, at one concentration (the size of the read-out at that concentration, not a potency): 100%
The estimate for compound 4 lay 3 percentage points below the measured number; low and high end bracket the measured number.
By their numbers in this assay, from the lowest: compounds 1, 3, 4 and 2 (each within the scatter of the next).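

In this assay, the step of a number 2 percentage points lower from compound 2 to compound 4 (within the scatter) shows that replacing 3,4-dichlorophenyl with 4-methoxyphenyl on this carbonyl carbon leaves the read-out flat, even though the swap removes chlorine, brings in oxygen and adds a hydrogen-bond acceptor. The step of a number 5 percentage points higher from compound 1 to compound 4 (within the scatter) shows that methoxy and amino on the aromatic carbon of this ring cannot be told apart either, so 4-aminophenyl, 3,4-dichlorophenyl and 4-methoxyphenyl now all give read-outs that lie within the scatter of one another at the one concentration tested. No supporting data are available to explain this flat result.

The compounds shown leave open whether any group at this position can move the read-out, for instance a carboxylic acid on the phenyl ring, a morpholine ring, or a longer alkyl chain in place of the aryl group on the carbonyl carbon. They also leave open whether these three aryl groups would separate at higher concentrations, as a single-concentration read-out gives no measure of potency.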